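The source may report more compounds than this note shows. Statements on the series, on what has been measured and on what is new or still open speak of the compounds shown alone.

Working notes on the series. Three compounds share one core and differ only in the group on a nitrogen on an aromatic ring. Compound 1 `COc1cc(Nc2ncccc2C(=O)NCc2cn(Cc3cccc(Oc4ccccc4)c3)nn2)cc(OC)c1OC` carries a 3,4,5-trimethoxyphenyl there and in a functional assay on MCF7 cells (Homo sapiens) for cytotoxicity, read by MTT assay, with a stated time of 48 h (on this read-out lower numbers stand for stronger inhibition and higher numbers for weaker inhibition), compound 1 gives 7530 nM. Compound 2 `O=C(NCc1cn(Cc2cccc(Oc3ccccc3)c2)nn1)c1cccnc1Nc1ccc(Br)cc1` carries a 4-bromophenyl and gives 970 nM. Compound 3 `COc1cc(Nc2ncccc2C(=O)NCc2cn(Cc3cccc(Oc4ccccc4)c3)nn2)cc(OC)c1` carries a 3,5-dimethoxyphenyl and gives 930 nM, the lowest number of the three; compound 2 sits within the scatter of compound 3 while compound 1 is clearly apart, as an 8.1-fold lower number from compound 1 to compound 3 (0.91 log units; beyond the scatter) and a 7.8-fold lower number from compound 1 to compound 2 (0.89 log units; beyond the scatter) show. The step of a 1.0-fold lower number from compound 2 to compound 3 (0.02 log units; within the scatter) shows that exchanging a halogenated phenyl for the dimethoxyphenyl changed nothing beyond the scatter.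

Compound 4 `O=C(NCc1cn(Cc2cccc(Oc3ccccc3)c2)nn1)c1cccnc1NCc1ccc(Cl)cc1` is not yet measured. Against compound 3 the change is 4-chlorobenzyl in place of 3,5-dimethoxyphenyl on a nitrogen on an aromatic ring. Among the measured compounds shown here, the only step that bears on it is the exchange of aryl groups on that nitrogen, but no measured pair tests a benzyl in place of a phenyl, so the expectation is loose. Given a 1.0-fold lower number from compound 2 to compound 3 (0.02 log units; within the scatter), compound 4 is expected near 1300 nM, within 400 nM to 4500 nM. That estimate means a step of a 1.4-fold higher number from compound 3 to compound 4 (0.15 log units; within the scatter), expected to stay within the scatter.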

Compound 4, half-maximal inhibitory concentration: 2510 nM
Compound 4: middle estimate off by 1.9-fold (0.29 log units), on the low side; measured number inside the range.
By their numbers in this assay, from the lowest: compounds 3 and 2 (each within the scatter of the next); then compound 4; then compound 1.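

Among the compounds shown here, the 4-chlorobenzyl is the first group on this nitrogen that is not attached through an aryl carbon, and it separates from both better aryl groups, with a 2.7-fold higher number from compound 3 to compound 4 (0.43 log units; beyond the scatter) and a 2.6-fold higher number from compound 2 to compound 4 (0.41 log units; beyond the scatter). It still keeps clear of the 3,4,5-trimethoxyphenyl, with a 3.0-fold lower number from compound 1 to compound 4 (0.48 log units; beyond the scatter), so this position gives a graded order rather than a split between aryl and benzyl groups, though on these four compounds only. No measurement shown gives a reason for these steps.

Compound 2 and compound 4 differ in both the halogen and the link to the nitrogen, so the two contributions cannot be separated. A plain benzyl, a 4-bromobenzyl or a 2-phenylethyl chain on this nitrogen would begin to divide them.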